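Swapping the aryl group on a sulfamoylacetamide-linked core

This account rests on a few compounds, and the source may have more. Where it says the series, first, only, none or still open, it means among the compounds named here.

Of the compounds shown here, two sharing one core have been measured in an assay for inhibition of Indoleamine 2,3-dioxygenase 1 (Homo sapiens), read by fluorescence, with a stated time of 24 h; on this read-out lower numbers stand for stronger inhibition and higher numbers for weaker inhibition. Compound 1 `NS(=O)(=O)CC(=O)NCCSc1nonc1/C(=N/O)Nc1cccc(Cl)c1` gives 10 nM in this assay, and compound 2 `C[C@H](CSc1nonc1/C(=N/O)Nc1ccc(F)c(Br)c1)NC(=O)CS(N)(=O)=O` gives 12 nM. Compound 1 has the lowest of the two numbers, but the gap to compound 2 lies within the usual scatter, so the two cannot be ordered against each other.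

Compound 3 `N#Cc1cc(N/C(=N\O)c2nonc2SCCNC(=O)CS(N)(=O)=O)ccc1F` has not yet been measured. It differs from compound 1 in one place: 3-cyano-4-fluorophenyl in place of 3-chlorophenyl on an amine nitrogen. Within the data shown here, no step between measured compounds that differ in one place is available, so nothing measured bears directly on this change. Compound 2, which carries its own different aryl group on the same nitrogen, sits close to compound 1, which suggests that this part of the molecule tolerates variation.

On that basis the step from compound 1 to compound 3 is expected to be small, a 1.5-fold higher number from compound 1 to compound 3 (0.18 log units; within the scatter), with no clear direction beyond the scatter. Compound 3 is therefore estimated to give about 15 nM in this assay, within a range from 6 nM to 40 nM.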

Compound 3, half-maximal inhibitory concentration: 39 nM
Compound 3: the middle estimate sits 2.6-fold (0.41 log units) below what was measured, within the range that was stated.
By their numbers in this assay, from the lowest: compounds 1 and 2 (each within the scatter of the next); then compound 3.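

In this assay, among these compounds, the change on the amine nitrogen from 3-chlorophenyl to 3-cyano-4-fluorophenyl gives a 3.9-fold higher number from compound 1 to compound 3 (0.59 log units; beyond the scatter), the only step yet available at this position. Although modest, it lies beyond the scatter, so this position does not accept every aryl group without a measurable change in the read-out. The step removes a chlorine and adds both a nitrile and a fluorine in a single change, and no measurement available here explains why the number rises.

The compounds shown cannot tell whether the step follows the loss of the chlorine, the nitrile or the fluorine, a question that a 3-cyanophenyl or a 3-chloro-4-fluorophenyl group on the same nitrogen would help to separate. They also leave open whether the same aryl change would have a similar effect with another group at the far end of the chain, such as a carboxylic acid in place of the sulfamoyl group.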